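Cyclopropylamino to piperazinylethyl urea on the shared core

The source may report more compounds than this note shows. Statements on the series, on what has been measured and on what is new or still open speak of the compounds shown alone.

Measured so far:
compound 1 `COc1ncc(-c2ccc3nc(NC4CC4)sc3c2)cc1NS(=O)(=O)c1ccc(F)cc1` — 1330 nM
compound 2 `O=S(=O)(Nc1cc(-c2ccc3nc(NC4CC4)sc3c2)cnc1Cl)c1ccc(F)cc1` — "not determined" (no result reported)

For the measured compounds named here, in a functional assay on A549 cells (Homo sapiens) for antiproliferative activity, read by MTT assay, with a stated time of 72 h (on this read-out higher numbers stand for weaker inhibition and lower numbers for stronger inhibition), compound 1 gives 1330 nM, the only number in hand for this series. In this assay compound 2 `O=S(=O)(Nc1cc(-c2ccc3nc(NC4CC4)sc3c2)cnc1Cl)c1ccc(F)cc1` gives "not determined" (no result reported), so no comparison with compound 1 can be drawn from it. Compound 3 `COc1ncc(-c2ccc3nc(NC(=O)NCCN4CCN(C)CC4)sc3c2)cc1NS(=O)(=O)c1ccc(F)cc1` is the next entry; it differs from compound 1 in one place: (2-(4-methylpiperazin-1-yl)ethyl)carbamoyl in place of cyclopropyl on a nitrogen on an aromatic ring. Going by the values given here, no step between two measured compounds exists here, so the size of this change has no precedent. The expectation is a step within the usual scatter, with no clear direction, and the estimate for compound 3 in this assay is therefore 1800 nM, within 400 nM to 9000 nM. The expected step is a 1.4-fold higher number from compound 1 to compound 3 (0.13 log units; within the scatter), leaving compound 3 close to compound 1 pending the measurement.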

Compound 3, half-maximal inhibitory concentration: 550 nM
For compound 3 the middle estimate is 3.3-fold (0.51 log units) above the measured one; the range from low to high includes it.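

In this assay, the nitrogen on an aromatic ring accepts a much larger substituent than cyclopropyl without loss: (2-(4-methylpiperazin-1-yl)ethyl)carbamoyl, with 12 heavy atoms in place of 3, gives a 2.4-fold lower number from compound 1 to compound 3 (0.38 log units; beyond the scatter), a modest step and the first readable one in this series. This single exchange introduces the carbonyl, the ethyl chain and the methylpiperazine ring together, so the step cannot be assigned to any one of these parts. Nothing available explains the lower number.

As far as these compounds go, it remains open which part of the new group carries the step. A plain methyl urea on the same nitrogen, or the same ethyl chain ending in morpholine or a dimethylamino group, would separate the contribution of the carbonyl from that of the piperazine ring.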